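Iodo in Place of Methyl on an Aryl Urea

This account rests on a few compounds, and the source may have more. Where it says the series, first, only, none or still open, it means among the compounds named here.

Measured so far:
compound 1 `Cc1cccc(NC(=O)N[C@H](C)c2ccccc2)c1`: 100%
compound 2 `Cc1cccc(NC(=O)N[C@@H](C)c2ccccc2)c1`: 99%
compound 3 `CCCCCCc1ccc(NC(=O)N[C@H](C)c2ccccc2)cc1`: 100%

In an ADME assay on the whole organism with Oryza sativa as the target, tested at 0.1 uM (a higher number here means a weaker effect of the compound at the concentration tested, a lower number a stronger effect), compound 1 gives 100%, level at the digits shown with compound 3 and together with it the highest of the three numbers. Among the measured compounds shown here, the only step measured, a number 1 percentage points lower from compound 1 to compound 2 (within the scatter), rests on the fact that compounds 1 and 2 differ only in the configuration as drawn and stays within the scatter. Compound 4 `C[C@@H](NC(=O)Nc1cccc(I)c1)c1ccccc1` arises from compound 1 by iodo in place of methyl on an aromatic carbon. For the measured compounds named here, no measured step swaps a group on this ring, so there is no direct guide; the one measured step moved nothing beyond the scatter, and the same is expected here: a number 2 percentage points lower from compound 1 to compound 4 (within the scatter). Compound 4 is therefore estimated at 98%, with a range from 85% to 100%.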

Compound 4, a percentage reported as activity, at one concentration (the size of the read-out at that concentration, not a potency): 81%
Compound 4: the middle estimate sits 17 percentage points above what was measured; measured number outside the range, below it.
By their numbers in this assay, from the lowest: compound 4; then compounds 2, 1 and 3 (each within the scatter of the next).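

In this assay, iodo in place of methyl on an aromatic carbon gives a number 19 percentage points lower from compound 1 to compound 4 (beyond the scatter). This position is therefore not silent: exchanging a single heavy atom here shifts the read-out towards a stronger effect, whereas the change of configuration between compound 1 and compound 2 stayed within the scatter. Nothing at hand explains why this exchange has this effect.

Going by these compounds, whether a chloro or bromo group in the same place would shift the number as well remains open. So does whether iodo would do the same on the opposite configuration, that of compound 2.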